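Swapping the Aryl Group on the Saturated Ring Carbon

The compounds below may be only part of what the source reports. "The series", "measured", "known", "first", "only" and "open" are said of these compounds alone.

Compound 3 `COc1cc(C2=NN(C(C)=O)C(c3ccc(C(F)(F)F)cc3)O2)cc(OC)c1OC` was tested in a functional assay on BGC-823 cells (Homo sapiens) for antiproliferative activity, read by MTT assay, tested at 5 uM (on this read-out higher numbers stand for a stronger effect at the one concentration tested and lower numbers for a weaker effect), where compound 3 gives 3.4%. Among the three measured compounds it stands second highest. Compound 2 `COc1ccc(C2OC(c3cc(OC)c(OC)c(OC)c3)=NN2C(C)=O)c(OC)c1` gives -3.1%, and the step of a number 6.5 percentage points higher from compound 2 to compound 3 (within the scatter) lies within the scatter. Compound 1 `COc1cc(C2=NN(C(C)=O)C(c3c(Cl)cccc3Cl)O2)cc(OC)c1OC` gives 15.9%, and the step of a number 12.5 percentage points lower from compound 1 to compound 3 (beyond the scatter) lies beyond it, as does a number 19 percentage points lower from compound 1 to compound 2 (beyond the scatter).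

Compound 4 `COc1cc(C2=NN(C(C)=O)C(c3cccc(F)c3)O2)cc(OC)c1OC` differs from compound 3 in one place: 3-fluorophenyl in place of 4-(trifluoromethyl)phenyl on a saturated ring carbon. All three measured steps exchange the aryl group on this same saturated ring carbon. Only the exchange away from the 2,6-dichlorophenyl of compound 1 moved the read-out beyond the scatter, while the exchange between compound 2 and compound 3 did not. For the measured compounds named here, no measured compound carries 3-fluorophenyl, so there is no direct step for it. Compound 4 is therefore expected to give 3%, between -10% and 16%. That expectation amounts to a number 0.4 percentage points lower from compound 3 to compound 4 (within the scatter), a step estimated to stay within the scatter.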

Compound 4, a percentage reported as inhibition, at one concentration (the size of the read-out at that concentration, not a potency): 37.7%
Beside the measured number, compound 4's estimate is 34.7 percentage points below it; the whole stated range lies below it.
By their numbers in this assay, from the lowest: compounds 2 and 3 (each within the scatter of the next); then compound 1; then compound 4.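

For the compounds shown here, until this result, every exchange away from the 2,6-dichlorophenyl of compound 1 had lowered the read-out in this assay, but 3-fluorophenyl on the same saturated ring carbon raises it, with a number 21.8 percentage points higher from compound 1 to compound 4 (beyond the scatter). Going by these compounds alone, the rise is larger still against the two compounds that had sat within the scatter of each other, with a number 34.3 percentage points higher from compound 3 to compound 4 (beyond the scatter) and a number 40.8 percentage points higher from compound 2 to compound 4 (beyond the scatter), so this position spans a much wider range than the earlier compounds showed, and 2,6-dichlorophenyl does not mark its upper end. Nothing available on these compounds accounts for the size of this rise.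

The compounds shown leave open whether the gain belongs to the fluorine itself or to the 3-fluorophenyl group as a whole. On these data alone, how an unsubstituted phenyl, a 4-fluorophenyl or a 3-aminophenyl would read on this carbon also remains open.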